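Methoxymethyl on the Phenyl Ring of a Cyclic Carbamate

A few compounds are considered here, and "the series" means these few. Any claim that something is new, unique, unknown or untested is made for them only; others in the source may bear on it.

The three measured compounds share one core: a ring bearing a carbonyl, a chain ending in a carboxylic acid, and an unsaturated side arm carrying a hydroxyl and a phenyl ring. Compound 1 has the structure `O=C(O)CCCSCCN1C(=O)SC[C@@H]1/C=C/[C@@H](O)Cc1ccccc1`. Compound 2, `O=C(O)CCCSCCN1C(=O)OC[C@@H]1/C=C/[C@@H](O)Cc1ccccc1`, replaces a sulfur in the ring with oxygen. Compound 3, `O=C(O)CCCSCCN1C(=O)SC[C@@H]1/C=C/[C@@H](O)Cc1cccc(C(F)(F)F)c1`, carries a trifluoromethyl on the phenyl ring. In an assay on CHO cells for displacement of a labelled ligand from prostaglandin E2 receptor EP2 subtype (Mus musculus), read by scintillation counting, with a stated time of 60 min (on this read-out lower numbers stand for stronger inhibition and higher numbers for weaker inhibition), compound 1 gives only a limit, > 10000 nM. In this assay compound 2 likewise gives only a limit, > 10000 nM. Compound 3 also gives only a limit, > 10000 nM. The step from compound 1 to compound 3, a step that the two limits leave unreadable from compound 1 to compound 3, cannot be sized because the limit of > 10000 nM in this assay, at which 3 of the 3 values shown sit, is where both compounds sit.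

Compound 4, `COCc1cccc(C[C@H](O)/C=C/[C@H]2COC(=O)N2CCSCCCC(=O)O)c1`, is the unmeasured partner of compound 2. The change is methoxymethyl in place of hydrogen on an aromatic carbon. Going by the values given here, the one related step, trifluoromethyl in place of hydrogen, gave no readable size, so no direction can be drawn from it. Given the limit at which compound 2 sits, compound 4 is expected to remain weak, with an estimated step that the limit leaves unreadable from compound 2 to compound 4. Compound 4 is therefore estimated at 15000 nM, within a range from 3000 nM to 100000 nM.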

Compound 4, inhibition constant: > 10000 nM
Compound 4: a limit, no number; the forecaster's own chance of this, stated with the estimate: 85%; the middle value does not contradict the limit.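

In this assay compound 4 gives only a limit, > 10000 nM. The step from compound 2 to compound 4 therefore cannot be sized, since neither compound has a readable number: the limit of > 10000 nM in this assay, at which 4 of the 4 values shown sit.

The compounds shown leave open whether methoxymethyl or any other group on the phenyl ring changes binding at all, since every result is a limit.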